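A few compounds are considered here, and "the series" means these few. Any claim that something is new, unique, unknown or untested is made for them only; others in the source may bear on it.

Measured so far:
compound 1 `O=C1Nc2ccccc2C1(c1c[nH]c2ccccc12)c1c[nH]c2ccccc12` gives 20400 nM in this set
compound 2 `COc1cccc2[nH]cc(C3(c4c[nH]c5cccc(OC)c45)C(=O)Nc4ccccc43)c12` gives 9000 nM in this set
compound 3 `O=C1Nc2ccccc2C1(c1c[nH]c2ccc(Cl)cc12)c1c[nH]c2ccc(Cl)cc12` gives 14600 nM in this set

All three numbers come from a functional assay on HepG2 cells (Homo sapiens) for cytotoxicity, read by MTT assay, with a stated time of 48 h (on this read-out lower numbers stand for stronger inhibition and higher numbers for weaker inhibition), and can be compared directly. Compound 1 sits within the usual scatter of compound 3, while compound 2 shows a lower number than compound 1, by a gap beyond that scatter.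

Compound 4 `O=C1Nc2ccc(F)cc2C1(c1c[nH]c2ccccc12)c1c[nH]c2ccccc12` has not been measured yet. Its structure departs from that of compound 1 in one place: the change fluoro in place of hydrogen on an aromatic carbon puts fluoro in place of hydrogen on an aromatic carbon.

For the measured compounds named here, no two measured compounds differ in just one place, so nothing here measures this kind of step directly. Going by the values given here, the only guide is the narrow spread of the set. Compound 3 at 14600 nM differs from compound 1 in more than one place yet stays within the scatter, and compound 2 at 9000 nM lies only a little beyond it. A small step is therefore expected in this assay, slightly downward or none beyond the scatter. The estimated 1.5-fold lower number from compound 1 to compound 4 (0.16 log units; within the scatter) is expected to stay within the scatter. Compound 4 is estimated at 14000 nM with an expected range of 6500 nM to 28000 nM around it.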

Compound 4, half-maximal inhibitory concentration: 6600 nM
For compound 4 the middle estimate is 2.1-fold (0.33 log units) above the measured one; the measured number falls inside the stated range.
By their numbers in this assay, from the lowest: compounds 4, 2, 3 and 1 (each within the scatter of the next, the first and the last beyond it).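

In this assay, for the compounds shown here, swapping hydrogen for fluoro on an aromatic carbon of the shared core brings a 3.1-fold lower number from compound 1 to compound 4 (0.49 log units; beyond the scatter) and gives the set its only single-change comparison. The earlier compounds shown here each differed from compound 1 in more than one place, so they could not show what one substitution does. This step shows that the position is not silent: one added fluorine atom, with no new ring, no net charge and no hydrogen-bond donor or acceptor, moves the number by a modest but real amount, and nothing available explains why.

Going by these compounds, it remains open whether the effect belongs to fluoro specifically or whether an amine or a carboxylic acid on the same carbon would shift the number as much, less or the other way. It is also unknown whether adding fluoro to compound 2 or compound 3 would produce a similar step.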